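Swapping the aryl group on the piperazine of compound 2

The source may hold more compounds than are shown below. What is called first, only, known or untested is meant among the compounds shown, and "the series" means these compounds.

Compound 2 `CN(C)C(=O)c1cccnc1NCCCN1CCN(c2ccccc2C#N)CC1`: 2 nM
Compound 3 `CN(C)C(=O)c1cccnc1NCCCN1CCN(c2ccccc2-c2ccccc2)CC1`: 1.26 nM
Compound 1 `COc1ccccc1N1CCN(CCCNc2ccc(C(=O)N(C)C)cn2)CC1`: 25.1 nM

In a functional assay for antagonist activity at Alpha-1A adrenergic receptor (Oryctolagus cuniculus) (on this read-out lower numbers stand for tighter binding and higher numbers for weaker binding), compound 2 holds the second highest of the three numbers; compound 3 lies closest, a 1.6-fold lower number from compound 2 to compound 3 (0.20 log units; within the scatter), while compound 1 is the furthest, beyond the scatter. Compound 4 `COc1cc(O)ccc1N1CCN(CCCNc2ncccc2C(=O)N(C)C)CC1` differs from compound 2 in one place: 4-hydroxy-2-methoxyphenyl in place of 2-cyanophenyl on an amine nitrogen in a ring. For the measured compounds named here, the only measured step, phenyl in place of cyano, does not swap the whole aryl group, so it bears on this change only loosely. Compound 1 carries a methoxyphenyl on a different core and gives 25.1 nM, which hints that a methoxy-bearing aryl group can be tolerated. For compound 4 a modest upward step, a 2.5-fold higher number from compound 2 to compound 4 (0.40 log units; beyond the scatter), is expected, giving an estimate of 5 nM within 1.5 nM to 20 nM.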

Compound 4, dissociation constant: 12.6 nM
Compound 4: middle estimate off by 2.5-fold (0.40 log units), on the low side; low and high end bracket the measured number.
By their numbers in this assay, from the lowest: compounds 3 and 2 (each within the scatter of the next); then compounds 4 and 1 (each within the scatter of the next).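

Putting 4-hydroxy-2-methoxyphenyl in place of 2-cyanophenyl on the amine nitrogen in the ring gives a 6.3-fold higher number from compound 2 to compound 4 (0.80 log units; beyond the scatter), which means weaker binding. For the compounds shown here, this is the first change at this position to go beyond the scatter, whereas the earlier step, a 1.6-fold lower number from compound 2 to compound 3 (0.20 log units; within the scatter), did not, so this position is not indifferent to the aryl group it carries. Nothing measured here accounts for the weaker binding.

The compounds shown do not separate the effect of the hydroxy group from that of the methoxy group on the shared core. On these data alone, how an amine or a carboxylic acid on this aryl ring would fare also remains open.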